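This account rests on a few compounds, and the source may have more. Where it says the series, first, only, none or still open, it means among the compounds named here.

Measured compounds in an assay on isolated protein for inhibition of Amine oxidase [flavin-containing] B (Homo sapiens), read by fluorescence, with stated times of 15 min and 20 min; a lower number here means a stronger inhibitor, a higher number a weaker inhibitor:
compound 1 `Cc1ccccc1CN1CCC(CCNC(=O)/C=C/c2cc(C(C)(C)C)c(O)c(C(C)(C)C)c2)CC1` — 7200 nM
compound 2 `CC(C)(C)c1cc(/C=C/C(=O)NCCC2CCN(Cc3cccc([N+](=O)[O-])c3)CC2)cc(C(C)(C)C)c1O` — 12500 nM

Going by the values given here, compound 2 gives the highest of the two numbers; its only neighbour is compound 1, and the step of a 1.7-fold higher number from compound 1 to compound 2 (0.24 log units; within the scatter) stays within the scatter, so the two are not separated. Compound 3 `CC(C)(C)c1cc(/C=C/C(=O)NCCC2CCN(Cc3ccc(C#N)cc3)CC2)cc(C(C)(C)C)c1O` is not yet measured. It differs from compound 2 by 4-cyanophenyl in place of 3-nitrophenyl on a saturated chain carbon bound to an amine nitrogen in a ring. Among the compounds with values here, the one measured step that bears on a change of the aryl group at this place is a 1.7-fold higher number from compound 1 to compound 2 (0.24 log units; within the scatter), which did not move the number beyond the scatter; no comparison of a 4-cyanophenyl with a 3-nitrophenyl is available. On that basis no step beyond the scatter is expected for compound 3, and the estimated step of a 1.3-fold lower number from compound 2 to compound 3 (0.12 log units; within the scatter) is small. Compound 3 is therefore expected at about 9500 nM, in the range 4000 nM to 25000 nM.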

Compound 3, half-maximal inhibitory concentration: 13900 nM
The estimate for compound 3 lay 1.5-fold (0.17 log units) below the measured number; the range from low to high includes it.
By their numbers in this assay, from the lowest: compounds 1, 2 and 3 (each within the scatter of the next).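

In this assay, a third aryl group on a saturated chain carbon bound to an amine nitrogen in a ring gives no separation: exchanging 3-nitrophenyl for 4-cyanophenyl yields a 1.1-fold higher number from compound 2 to compound 3 (0.05 log units; within the scatter). The wider comparison with the 2-methylphenyl group, a 1.9-fold higher number from compound 1 to compound 3 (0.29 log units; within the scatter), also stays within the scatter, so methyl, nitro and nitrile substituents at the positions printed in these names are not told apart in this series. No independent data bear on this result.

Going by these compounds, all three compounds carry a substituted phenyl at this place, so it remains open whether an unsubstituted benzyl, a plain methyl on the amine nitrogen or a carboxylic acid on the phenyl ring would move the number beyond the scatter. Also open, on these data alone, is whether a 3-cyanophenyl would differ from the 4-cyanophenyl, as the same substituent is not compared at two ring positions.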